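The source may report more compounds than this note shows. Statements on the series, on what has been measured and on what is new or still open speak of the compounds shown alone.

Measured in a functional assay on MCF7 cells (Homo sapiens) for antiproliferative activity, read by MTT assay, with a stated time of 72 h; a higher number here means a weaker inhibitor, a lower number a stronger inhibitor:
- Compound 1 `C#CCCOC(=O)c1ccc(C(CC)(CC)c2ccc(C#CC(O)(CC)CC)c(C)c2)n1CC`: > 50000 nM (a limit)
- Compound 2 `CCn1cc(C(CC)(CC)c2ccc(C#CC(O)(CC)CC)c(C)c2)cc1C(=O)NCCN(C)C`: 13400 nM

Among the measured compounds shown here, only two compounds have been measured in this assay, and they share the same core. Compound 1 gives > 50000 nM, which is a limit and not a number. For the measured compounds named here, compound 2 gives 13400 nM, the only actual number available, so there is no measured series against which to place it.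

Compound 3 `CCn1cc(C(CC)(CC)c2ccc(C#CC(O)(CC)CC)c(C)c2)cc1C(=O)N[C@H](C(=O)O)C(C)C` has not yet been measured. It differs from compound 2 at the amide: 1-carboxy-2-methylpropyl stands in place of 2-(dimethylamino)ethyl on an amide-type nitrogen (1-carboxy-2-methylpropyl in place of 2-(dimethylamino)ethyl on an amide-type nitrogen). Going by the values given here, no step between measured compounds shows what such a change does.

The expectation therefore rests on little. Compound 2 stands at 13400 nM. The only other result, that of compound 1, is a limit on the weak side. A moderate shift towards weaker inhibition is therefore expected, and compound 3 may also end up reported only as a limit. The expected step is a 2.2-fold higher number from compound 2 to compound 3 (0.35 log units; beyond the scatter). For compound 3 the estimated value is 30000 nM, with an expected range from 12000 nM to 80000 nM.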

Compound 3, half-maximal inhibitory concentration: 12600 nM
Compound 3: the middle estimate sits 2.4-fold (0.38 log units) above what was measured; low and high end bracket the measured number.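

In this assay, setting 1-carboxy-2-methylpropyl in place of 2-(dimethylamino)ethyl on the amide-type nitrogen gives a 1.1-fold lower number from compound 2 to compound 3 (0.03 log units; within the scatter). Among the compounds shown here, this is the only step that can be read at this position, and it shows that these two groups, which differ in heavy atoms, in hydrogen-bond donors and in the defined stereocentre of the entering group, cannot be told apart in this read-out. Compound 2 and compound 3 both give actual numbers, and the one limit in the set belongs to compound 1: the limit of > 50000 nM in this assay, at which 1 of the 3 values shown sits.

The single exchange removes the dimethylamino group and brings in the carboxylic acid and the isopropyl branch together, so the compounds shown do not separate what each of these parts contributes, and the mirror-image form of the entering group is also absent from them. From the compounds shown here alone, it also stays open whether a morpholine ring at the end of the chain, a longer chain carrying an amine, or a plain methyl group on the amide-type nitrogen would read any differently from compound 2 and compound 3.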